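Replacing acetyl by 2-chlorobenzoyl on compound 1

The source may hold more compounds than are shown below. What is called first, only, known or untested is meant among the compounds shown, and "the series" means these compounds.

Going by the values given here, compound 1 `CC(=O)/N=C1\NC2(CCCCO2)CCS1` gives 3.1 mg/kg in a functional assay on the whole organism (strain CF-1) with Mus musculus as the target, in the writhing test, with a stated time of 15 min (a lower number here means that less compound is needed, a higher number that more compound is needed for the effect), the only number among the three values shown. Compound 2 `c1ccc(/N=C2\NC3(CCCCO3)CCS2)cc1` reaches only a limit, > 200 mg/kg, in this assay. Compound 3 `O=C(/N=C1\NCCCS1)c1ccc(F)cc1` likewise stops at a limit, > 100 mg/kg. Among the compounds with values here, the single measured step, an at least 64-fold higher number from compound 1 to compound 2 (1.80 log units; beyond the scatter), ends at the limit of > 200 mg/kg in this assay, at which 1 of the 3 values shown sits. Compound 4 `O=C(/N=C1\NC2(CCCCO2)CCS1)c1ccccc1Cl` differs from compound 1 by 2-chlorophenyl in place of methyl on a carbonyl carbon. Enlarging the group on the double-bonded nitrogen drove compound 2 past the limit, and compound 3, carrying an aromatic ring on its carbonyl carbon on a different core, sits at the limit of > 100 mg/kg in this assay, at which 1 of the 3 values shown sits; no step links compound 3 to compound 1. Compound 4 is therefore expected to need a higher dose, with a 13-fold higher number from compound 1 to compound 4 (1.11 log units; beyond the scatter) and a fair chance of a limit only. The estimate for compound 4 is 40 mg/kg, range 8 mg/kg to 200 mg/kg.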

Compound 4, dose for half-maximal effect: > 200 mg/kg
Compound 4: only a limit was reported (the forecaster's own chance of this, stated with the estimate: 45%); middle value at least 5.0-fold (0.69 log units) from the limit.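

With the carbonyl kept, 2-chlorophenyl in place of methyl on a carbonyl carbon still gives an at least 64-fold higher number from compound 1 to compound 4 (1.80 log units; beyond the scatter) in this assay. The carbonyl alone therefore does not hold the low dose, which the earlier phenyl change on the double-bonded nitrogen could not show, as that change removed the carbonyl as well. Compound 4 gives only a limit, not a number: the limit of > 200 mg/kg in this assay, at which 2 of the 4 values shown sit.

As far as these compounds go, how far the group on the carbonyl carbon can grow from methyl stays open: ethyl, cyclopropyl or unsubstituted phenyl would help locate the loss. With only limits at this end, no order can be read among the larger groups.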